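Phenyl for Hydrogen on a Core Showing No Inhibition

The source may hold more compounds than are shown below. What is called first, only, known or untested is meant among the compounds shown, and "the series" means these compounds.

Compound 1, `O=C(NC1CCCCCC1)c1c(-c2ccccc2)c(Br)cn(Cc2ccc(F)cc2)c1=O`: in an ADME assay on cells for inhibition of Fatty-acid amide hydrolase 1 (Homo sapiens), with stated times of 30 min and 15 min (on this read-out higher numbers stand for weaker inhibition and lower numbers for stronger inhibition), compound 1 gives > 10000 nM, a limit of the assay.
Compound 2, `O=C(NC1CCCCCC1)c1c(-c2ccccc2)ccn(Cc2ccc(F)cc2)c1=O`: in this assay compound 2 gives > 10000 nM, again a limit.

Both values sit at the same edge: the limit of > 10000 nM in this assay, at which 2 of the 2 values shown sit. Compound 2 therefore has no place on the scale that can be read; it is known only to be at most a weak inhibitor. Within the data shown here, the one measured step, a step that the two limits leave unreadable from compound 1 to compound 2, cannot be read either. Compound 3, `O=C(NC1CCCCCC1)c1c(-c2ccccc2)c(-c2ccccc2)cn(Cc2ccc(F)cc2)c1=O`, differs from compound 2 by phenyl in place of hydrogen on an aromatic carbon. Among the measured compounds shown here, no measured step bears on this change: the single step available is unreadable. The expectation in this assay is that compound 3 stays near the limit. The expected step is a number no higher from compound 2 to compound 3 (the limit leaves the size open), an estimate rather than a reading. The estimate for compound 3 is 10000 nM, within 2000 nM to 50000 nM.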

Compound 3, half-maximal inhibitory concentration: > 10000 nM
Compound 3: a limit, no number; the forecaster's own chance of this, stated with the estimate: 70%; the middle value lies on the limit itself.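

Neither new step, from compound 2 to compound 3 or from compound 1 to compound 3, can be read, because all three compounds share one limit: the limit of > 10000 nM in this assay, at which 3 of the 3 values shown sit.

The compounds shown leave open how strongly any of them inhibits the enzyme, and whether bromo, hydrogen or phenyl at this place makes any difference.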